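From Nitrophenyl to Phenylethenyl on a Shared Core

This account rests on a few compounds, and the source may have more. Where it says the series, first, only, none or still open, it means among the compounds named here.

Compound 1, `O=C(O)c1ccccc1C1CC(c2cc3ccccc3o2)=NN1C(=O)c1ccncc1`: > 170000 nM in an ADME assay on Vero cells (Chlorocebus sabaeus) for cytotoxicity, read by MTT assay, with a stated time of 72 h (a lower number here means a stronger inhibitor, a higher number a weaker inhibitor), a limit.
Compound 2, `O=C(c1ccncc1)N1N=C(c2cc3ccccc3o2)CC1c1ccccc1[N+](=O)[O-]`: > 245000 nM in this assay, a limit.

Compound 2 stands at a limit in this assay, and compound 1 likewise sits at its own limit (the limit of > 170000 nM in this assay, at which 1 of the 2 values shown sits); both values shown are limits (the limit of > 245000 nM in this assay, at which 1 of the 2 values shown sits). The step that the two limits leave unreadable from compound 1 to compound 2 is therefore unreadable. Compound 3 `O=C(c1ccncc1)N1N=C(c2cc3ccccc3o2)CC1/C=C/c1ccccc1` differs from compound 2 by 2-phenylethenyl in place of 2-nitrophenyl on a saturated ring carbon. Among the measured compounds shown here, no measured step bears readably on this change, so nothing beyond the scatter is expected. Compound 3 is estimated at 300000 nM in this assay, within 100000 nM to 1000000 nM, a step that the limit leaves unreadable from compound 2 to compound 3.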

Compound 3, half-maximal inhibitory concentration: > 212000 nM
Compound 3: a limit, no number; the forecaster's own chance of this, stated with the estimate: 75%; the middle value does not contradict the limit.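

In this assay compound 3 gives > 212000 nM, a limit. Among the compounds shown here, compound 1, compound 2 and compound 3 all stand at limits, so no step among them can be read. The compounds shown leave open what size of inhibitory concentration goes with any of the three groups compared on the saturated ring carbon.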